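Swapping a Bromine Anilide for a Methyl One

A few compounds are considered here, and "the series" means these few. Any claim that something is new, unique, unknown or untested is made for them only; others in the source may bear on it.

Measured compounds: compound 1 `O=C(CSc1nc(Nc2ccccc2)c2ccccc2n1)Nc1ccc(F)c(Cl)c1` gives 20900 nM in a functional assay on MGC-803 cells (Homo sapiens) for inhibition, read by MTT assay, with a stated time of 72 h; on this read-out lower numbers stand for stronger inhibition and higher numbers for weaker inhibition; compound 2 `C=CC(=O)Nc1cccc(NC(=O)CSc2nc(Nc3ccccc3Br)c3ccccc3n2)c1` gives 12800 nM in this assay.

Compound 2 has the lowest of the two numbers, but its gap to compound 1 is within the scatter, so the two cannot be told apart. Compound 3 `C=CC(=O)Nc1cccc(NC(=O)CSc2nc(Nc3cccc(C)c3)c3ccccc3n2)c1` differs from compound 2 only in 3-methylphenyl in place of 2-bromophenyl on a nitrogen on an aromatic ring. Among the measured compounds shown here, no measured pair shows this change, so no step size is known; a change beyond the scatter is not expected in this assay, in either direction. Compound 3 is therefore estimated at 14000 nM, between 5000 nM and 40000 nM, a step of a 1.1-fold higher number from compound 2 to compound 3 (0.04 log units; within the scatter) that is expected to stay within the scatter.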

Compound 3, half-maximal inhibitory concentration: 20900 nM
Compound 3: the middle estimate sits 1.5-fold (0.17 log units) below what was measured, and the stated range covers the measured number.
By their numbers in this assay, from the lowest: compounds 2, 1 and 3 (each within the scatter of the next).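

Among the compounds shown here, this is the first measured pair that differs only at this nitrogen. In this assay, 3-methylphenyl in place of 2-bromophenyl gives a 1.6-fold higher number from compound 2 to compound 3 (0.21 log units; within the scatter), so this exchange of one aromatic group for another does not separate the two compounds. Nothing available explains this outcome.

On these data alone, both groups are substituted phenyl rings, so it remains open whether a different kind of group on this nitrogen, such as a longer alkyl chain or a phenyl ring carrying an amine or a carboxylic acid, would move the number beyond the scatter.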